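The source may report more compounds than this note shows. Statements on the series, on what has been measured and on what is new or still open speak of the compounds shown alone.

In a functional assay on PC-3 cells (Homo sapiens) for inhibition, read by MTT assay, with a stated time of 72 h (on this read-out higher numbers stand for weaker inhibition and lower numbers for stronger inhibition), three compounds have been measured. Compound 1 `O=C(CSc1nc(Nc2ccccc2)c2ccccc2n1)Nc1ccc(F)cc1` gives 9560 nM, compound 2 `O=C(CSc1nc(Nc2ccccc2)c2ccccc2n1)Nc1ccc(Cl)c(Cl)c1` gives 12100 nM, and compound 3 `C=CC(=O)Nc1cccc(NC(=O)CSc2nc(Nc3ccccc3Cl)c3ccccc3n2)c1` gives 14400 nM. Within the data shown here, the single one-place step among them, a 1.3-fold higher number from compound 1 to compound 2 (0.10 log units; within the scatter), changes a group on an amide-type nitrogen and stays within the scatter. Compound 3 has the highest of the three numbers, but its gaps to compound 2 and to compound 1 are both within the scatter, so the three compounds cannot be told apart on this assay.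

Compound 4 `C=CC(=O)Nc1cccc(NC(=O)CSc2nc(Nc3ccc(Cl)cc3)c3ccccc3n2)c1` differs from compound 3 by 4-chlorophenyl in place of 2-chlorophenyl on a nitrogen on an aromatic ring. Among the measured compounds shown here, no measured step touches this nitrogen, and the one known step, between compound 1 and compound 2, lies elsewhere and is itself within the scatter. There is therefore no basis to expect a shift in this assay beyond the scatter, in either direction. The step of a 1.2-fold lower number from compound 3 to compound 4 (0.08 log units; within the scatter) is expected to be small. Compound 4 is estimated at 12000 nM, with a range from 5000 nM to 30000 nM.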

Compound 4, half-maximal inhibitory concentration: 10800 nM
Beside the measured number, compound 4's estimate is 1.1-fold (0.05 log units) above it; low and high end bracket the measured number.
By their numbers in this assay, from the lowest: compounds 1, 4, 2 and 3 (each within the scatter of the next).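

Among these compounds, this is the first measured step at the nitrogen on an aromatic ring: in this assay, 4-chlorophenyl in place of 2-chlorophenyl gives a 1.3-fold lower number from compound 3 to compound 4 (0.12 log units; within the scatter). Among the compounds shown here, for this pair, then, the two chlorophenyl groups cannot be told apart, and the same holds for the one earlier step, on the amide-type nitrogen, a 1.3-fold higher number from compound 1 to compound 2 (0.10 log units; within the scatter). Nothing shown here bears on why these two compounds read alike.

Still open, from the compounds shown here alone, is whether a group of another kind on this nitrogen, such as a 4-methoxyphenyl ring or an ethyl chain, would give a number clearly apart from those of compound 3 and compound 4. Also open, going by these compounds, is whether the chlorine itself matters, a question that a plain phenyl on this nitrogen, with the rest of compound 4 kept, could answer.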